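A few compounds are considered here, and "the series" means these few. Any claim that something is new, unique, unknown or untested is made for them only; others in the source may bear on it.

Of the compounds shown here, three that share one core have been measured in a functional assay on CHO cells for agonist activity at Free fatty acid receptor 1 (Homo sapiens), read by reporter gene assay; on this read-out higher numbers stand for larger maximal responses and lower numbers for smaller maximal responses. Compound 1 `O=C(O)CCc1ccc(NCc2ccc(Cl)cc2)cc1` gives 111%. Compound 2 `O=C(O)CCCc1ccc(NCc2cccc(Oc3ccccc3)c2)cc1` gives 74%. Compound 3 `O=C(O)CCc1ccc(NCc2ccc(-c3ccccc3)cc2)cc1` gives 111%. The change from compound 1 to compound 3, phenyl in place of chloro on an aromatic carbon, gave no change at the digits printed from compound 1 to compound 3 (within the scatter). Compound 3 therefore stands level with compound 1, the two together being the highest of the three numbers, while compound 2 sits clearly below both.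

Compound 4 `O=C(O)C1CC1c1ccc(NCc2ccc(-c3ccccc3)cc2)cc1` has not yet been measured. It differs from compound 3 in one place: 2-carboxycyclopropyl in place of 2-carboxyethyl on an aromatic carbon. Among the compounds with values here, the only measured step, from compound 1 to compound 3, concerns the phenyl and chloro groups and showed no change beyond the scatter; no measured step touches the 2-carboxyethyl group, so there is no direct guide for this change. With nothing pointing either way, the largest response of compound 4 in this assay is expected to stay near that of compound 3, with a step of a number 16 percentage points lower from compound 3 to compound 4 (beyond the scatter). Compound 4 is estimated at 95%, within a range from 60% to 120%.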

Compound 4, largest response reached (reported as percent of maximum), in percent of the reference or control that the assay uses: 80%
Beside the measured number, compound 4's estimate is 15 percentage points above it, and the stated range covers the measured number.
By their numbers in this assay, from the lowest: compounds 2 and 4 (each within the scatter of the next); then compounds 1 and 3 (each within the scatter of the next).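

In this assay, the group carrying the carboxylic acid proves sensitive to change: putting 2-carboxycyclopropyl in place of 2-carboxyethyl, on the aromatic carbon para to a large group, gave a number 31 percentage points lower from compound 3 to compound 4 (beyond the scatter), whereas phenyl in place of chloro at the other end of the molecule had given no change at the digits printed from compound 1 to compound 3 (within the scatter). Within the data shown here, this is therefore the first single change here to move the maximal response beyond the scatter, and it does so although both groups carry the same hydrogen-bond donor and acceptor counts and no net charge, so the clearest difference between them is the three-membered carbon ring. Nothing available explains why the response fell.

On these data alone, it remains open whether the fall belongs to the three-membered ring itself or would follow from any added carbon on this chain, a question that a cyclobutane ring bearing the carboxylic acid or a single methyl group on the 2-carboxyethyl chain could help to settle. Also open, as far as these compounds go, is whether the same step would appear with chloro in place of the phenyl group at the other end.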